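Replacing 2-bromophenyl with 3-methylphenyl: notes on compound 4

A few compounds are considered here, and "the series" means these few. Any claim that something is new, unique, unknown or untested is made for them only; others in the source may bear on it.

In a functional assay on HL-60 cells (Homo sapiens) for antiproliferative activity, with a stated time of 72 h (a higher number here means a weaker inhibitor, a lower number a stronger inhibitor), compound 1 `OC[C@H]1O[C@@H](n2cnc3c(NCc4ccccc4Cl)ncnc32)[C@H](O)[C@@H]1O` gives 1600 nM, compound 2 `OC[C@H]1O[C@@H](n2cnc3c(NCc4ccc(Cl)cc4)ncnc32)[C@H](O)[C@@H]1O` gives 1700 nM and compound 3 `OC[C@H]1O[C@@H](n2cnc3c(NCc4ccccc4Br)ncnc32)[C@H](O)[C@@H]1O` gives 6600 nM. Compound 3 has the highest number of the three and is the weakest inhibitor in this small set. Compound 2 differs from compound 1 by 4-chlorophenyl in place of 2-chlorophenyl, giving a 1.1-fold higher number from compound 1 to compound 2 (0.03 log units; within the scatter), so this pair does not separate. Bromo in place of chloro gives a 4.1-fold higher number from compound 1 to compound 3 (0.62 log units; beyond the scatter), and 2-bromophenyl in place of 4-chlorophenyl gives a 3.9-fold higher number from compound 2 to compound 3 (0.59 log units; beyond the scatter).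

Compound 4 `Cc1cccc(CNc2ncnc3c2ncn3[C@@H]2O[C@H](CO)[C@@H](O)[C@H]2O)c1` is the next case, with this difference from compound 3: 3-methylphenyl in place of 2-bromophenyl on a saturated chain carbon bound to a nitrogen on an aromatic ring. In words, 3-methylphenyl stands in place of 2-bromophenyl on a saturated chain carbon bound to a nitrogen on an aromatic ring. For the measured compounds named here, compound 3 is the only bromo compound measured, and the two steps leading to it are the closest guide, since both chloro compounds have lower numbers. Going by the values given here, no methyl compound has been measured, so only part of that modest gap is expected to be recovered. The estimated step is a 2.2-fold lower number from compound 3 to compound 4 (0.34 log units; beyond the scatter). For compound 4 the expected value is 3000 nM, with an estimated range of 1100 nM to 8500 nM.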

Compound 4, half-maximal inhibitory concentration: 6400 nM
The estimate for compound 4 lay 2.1-fold (0.33 log units) below the measured number, and the stated range covers the measured number.
By their numbers in this assay, from the lowest: compounds 1 and 2 (each within the scatter of the next); then compounds 4 and 3 (each within the scatter of the next).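

In this assay the measured step is a 1.0-fold lower number from compound 3 to compound 4 (0.01 log units; within the scatter), so on this saturated chain carbon 3-methylphenyl and 2-bromophenyl do not separate, and the higher number of compound 3 is no longer tied to bromo alone. The 3-methylphenyl group also stands apart from both chloro groups, with a 3.8-fold higher number from compound 2 to compound 4 (0.58 log units; beyond the scatter) and a 4.0-fold higher number from compound 1 to compound 4 (0.60 log units; beyond the scatter), so the four compounds form two pairs: the 2-chlorophenyl and 4-chlorophenyl compounds with lower numbers, the 2-bromophenyl and 3-methylphenyl compounds with higher ones, and none of the four goes against this split. No available data account for the split.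

Because 3-methylphenyl differs from each earlier group in both the substituent and its numbered ring position, the compounds shown leave open whether the split follows the substituent, the position or both; 3-chlorophenyl, 2-methylphenyl and 4-bromophenyl groups would test this directly. Also open, as far as these compounds go, is how far the series extends beyond halogen and methyl groups, for example to unsubstituted phenyl or to a phenyl ring carrying an amine or a carboxylic acid.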